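Methyl in Place of Hydroxy on Compound 2

The compounds below may be only part of what the source reports. "The series", "measured", "known", "first", "only" and "open" are said of these compounds alone.

In an in vitro assay on cells for inhibition of Amine oxidase [flavin-containing] B (Homo sapiens), read by Amplex Red, with a stated time of 15 min (on this read-out lower numbers stand for stronger inhibition and higher numbers for weaker inhibition), compound 1 `COc1ccc(/C=C/C=C/C(=O)c2ccccc2O)cc1` gives 1810 nM. Compound 2 `COc1cc(/C=C/C=C/C(=O)c2ccccc2O)ccc1O` gives 502 nM, the lower of the two numbers, and compound 1 stands higher by a margin beyond the usual scatter. Compound 3 `COc1ccc(/C=C/C=C/C(=O)c2ccccc2O)cc1OC` differs from compound 2 by methyl in place of hydrogen on an oxygen on an aromatic ring. The expected step of a 3.0-fold higher number from compound 2 to compound 3 (0.48 log units; beyond the scatter) lies beyond the scatter, towards weaker inhibition, because compound 1 in this assay gives 1810 nM. The estimate for compound 3 in this assay is 1500 nM, with a range from 600 nM to 4000 nM.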

Compound 3, half-maximal inhibitory concentration: 14600 nM
Estimate against measurement, compound 3: 9.7-fold (0.99 log units) below; measured number above the stated range.
By their numbers in this assay, from the lowest: compound 2; then compound 1; then compound 3.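

In this assay, methoxy in place of hydroxy on the aromatic ring is a large penalty (a 29-fold higher number from compound 2 to compound 3 (1.46 log units; beyond the scatter)). Compound 3 also stands apart from compound 1 (an 8.1-fold higher number from compound 1 to compound 3 (0.91 log units; beyond the scatter)), so at this position a methoxy gives weaker inhibition than either hydroxy or hydrogen on the aromatic carbon, with hydroxy clearly the better of the two oxygen groups. Nothing available explains the size of these steps. The compounds shown leave open how a longer chain on this oxygen, such as ethoxy, would read. They also leave open how an amine in place of the hydroxy would read.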